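Cyclohexyl to 3-methoxyphenyl on the imidazole side chain

The source may hold more compounds than are shown below. What is called first, only, known or untested is meant among the compounds shown, and "the series" means these compounds.

Measured so far:
compound 1 `O=C(O)c1ccccc1-c1ccc(CCc2ncc(CC3CCCCC3)[nH]2)cc1` with 7.3 nM
compound 2 `Cc1ccccc1Cc1cnc(CCc2ccc(-c3ccccc3C(=O)O)cc2)[nH]1` with 9.3 nM

In an in vitro functional assay on cells for agonist activity at Bombesin receptor subtype-3 (Mus musculus), read by luminescence and calcium flux (a higher number here means that more compound is needed for the effect, a lower number that less compound is needed), compound 1 gives 7.3 nM, the lowest of the two numbers at hand. Its nearest neighbour is compound 2, which in this assay gives 9.3 nM; the step of a 1.3-fold higher number from compound 1 to compound 2 (0.11 log units; within the scatter) lies within the scatter, so the two compounds cannot be told apart on these numbers.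

Compound 3 `COc1cccc(Cc2cnc(CCc3ccc(-c4ccccc4C(=O)O)cc3)[nH]2)c1` has not yet been measured in this assay. It differs from compound 1 in one place: 3-methoxyphenyl in place of cyclohexyl on a saturated chain carbon bound to an aromatic carbon. Among the measured compounds shown here, the only measured step that bears on this change is a 1.3-fold higher number from compound 1 to compound 2 (0.11 log units; within the scatter), where a 2-methylphenyl took the same position and the number barely moved. That single step says the saturated ring can be traded for an aromatic one without a shift beyond the scatter, though nothing measured speaks to the methoxy group itself. The expectation for compound 3 is therefore a step of a 1.4-fold higher number from compound 1 to compound 3 (0.14 log units; within the scatter), that is, no change beyond the scatter, with the range kept wide on account of the untested substituent. Compound 3 is thus estimated at 10 nM, between 4 nM and 30 nM.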

Compound 3, half-maximal effective concentration: 79 nM
Compound 3: the middle estimate sits 7.9-fold (0.90 log units) below what was measured; the whole stated range lies below it.
By their numbers in this assay, from the lowest: compounds 1 and 2 (each within the scatter of the next); then compound 3.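

In this assay, among the compounds shown here, the place on a saturated chain carbon bound to an aromatic carbon proves less forgiving than the first pair of compounds suggested: 3-methoxyphenyl in place of cyclohexyl gives an 11-fold higher number from compound 1 to compound 3 (1.03 log units; beyond the scatter), and 3-methoxyphenyl in place of 2-methylphenyl gives an 8.5-fold higher number from compound 2 to compound 3 (0.93 log units; beyond the scatter). An aromatic ring here is therefore not enough on its own to hold the number at the level of compound 1: compound 2 stays within the scatter of compound 1, whereas compound 3 does not, so the outcome depends on what the ring carries or where it carries it. Nothing at hand gives a measured explanation for this rise.

The rings of compound 2 and compound 3 differ both in their substituent and in where it sits, and the compounds shown do not separate these two differences. A phenyl ring with no substituent, or a methyl group in the place the methoxy group holds in 3-methoxyphenyl, would show which of the two goes with the higher number.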